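The source may hold more compounds than are shown below. What is called first, only, known or untested is meant among the compounds shown, and "the series" means these compounds.

Of the compounds shown here, three have been tested in a functional assay on the whole organism with Rattus norvegicus as the target, at a dose of 100 mg/kg; a higher number here means more inhibition at the dose given (going by the name of the read-out), a lower number less inhibition. Compound 1 `C/N=C(\S)NCCCCn1nc(C)ccc1=O` gives 44.5%. Compound 2 `N#CNC(=N)NCCCCCn1nc(-c2ccccc2)ccc1=O` gives 31%, and compound 3 `C/N=C(\S)NCCCCn1nc(-c2ccccc2)ccc1=O` gives 87.1%. Of these three numbers compound 1 holds the second highest place: it stands above compound 2 and well below compound 3.

Two single-change steps have been measured. Putting phenyl in place of methyl on an aromatic carbon gave a number 42.6 percentage points higher from compound 1 to compound 3 (beyond the scatter). Exchanging the head group at the end of the chain gave a number 56.1 percentage points higher from compound 2 to compound 3 (beyond the scatter), though in that step the chain between the core and the head group also shortened by one carbon, so the two changes cannot be separated.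

Compound 4 `C/N=C(\S)NCCCCCn1nc(C)ccc1=O` differs from compound 1 in one place: a group of 6 heavy atoms (3 carbon, 2 nitrogen, 1 sulfur; no ring) in place of a group of 5 heavy atoms (2 carbon, 2 nitrogen, 1 sulfur; no ring), on a saturated chain carbon, four bonds along the chain from an aromatic nitrogen. Going by the values given here, no measured step isolates this change. Compound 2 carries the longer chain, but its head group and its ring substituent both differ from those of compound 1, so its value alone does not show what the extra carbon does. With nothing to point either way, the expected change is a number 0.5 percentage points higher from compound 1 to compound 4 (within the scatter), that is, no step beyond the scatter. Compound 4 is therefore estimated to give 45% in this assay, with a range from 25% to 65%.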

Compound 4, a percentage reported as inhibition, in the whole organism at one dose (the size of the read-out at that dose, not a potency): 3.2%
Beside the measured number, compound 4's estimate is 41.8 percentage points above it; measured number below the stated range.
By their numbers in this assay, from the lowest: compound 4; then compound 2; then compound 1; then compound 3.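

Here, for the first time, the chain length changes on its own: with the methyl on the core and the sulfur-containing head group kept, putting the group of 6 heavy atoms in place of the group of 5 heavy atoms gives, in this assay, a number 41.3 percentage points lower from compound 1 to compound 4 (beyond the scatter). This makes the position on the saturated chain carbon, four bonds along the chain from an aromatic nitrogen, a sensitive one, since a change this small in a single chain moves the read-out far beyond the usual scatter. The result shows only the size and direction of the effect, and nothing shown explains why the longer chain gives so much less inhibition in the whole animal.

Still open, on these data alone, is whether the same lengthening would cost as much in a compound carrying phenyl in place of the methyl, since the effect of the chain has been read only with the methyl present. Also open, as far as these compounds go, is how a shorter chain, a still longer chain, or an amine as the head group would behave at this position.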